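A Fluorophenyl Group Replaces Hydrogen on the Saturated Ring

The source may hold more compounds than are shown below. What is called first, only, known or untested is meant among the compounds shown, and "the series" means these compounds.

Compound 2 `CN1CC(=O)N(C)c2cnc(Nc3ccc(S(N)(=O)=O)cc3)nc21` has the highest number of the two measured compounds in an assay on Sf9 cells for inhibition of serine/threonine-protein kinase 4 (Homo sapiens), read by luminescence and ADP-Glo, with a stated time of 1 h, in the presence of a further agent that is not named here (a higher number here means a weaker inhibitor, a lower number a stronger inhibitor), where compound 2 gives 495 nM. Its nearest neighbour is compound 1 `CN1C(=O)C(C2CC2)N(C)c2nc(Nc3ccc(S(N)(=O)=O)cc3)ncc21`, which in this assay gives 136 nM; the two differ only where compound 1 carries cyclopropyl on a saturated ring carbon, and the step of a 3.6-fold higher number from compound 1 to compound 2 (0.56 log units; beyond the scatter) shows that replacing that group with hydrogen raised the number. Compound 3 `CN1C(=O)C(c2ccc(F)cc2)N(C)c2nc(Nc3ccc(S(N)(=O)=O)cc3)ncc21` has not yet been measured. It differs from compound 2 by 4-fluorophenyl in place of hydrogen on a saturated ring carbon. Among the compounds with values here, the only measured step that bears on this change is the one from compound 1 to compound 2, in which a group other than hydrogen at the same saturated ring carbon went with a lower number, by a modest amount. On that basis, a group in place of hydrogen is again expected to lower the number beyond the scatter, although 4-fluorophenyl is not cyclopropyl and the size of the step is uncertain. Compound 3 is therefore expected to give 150 nM in this assay, with a likely range of 40 nM to 600 nM. This estimate means an expected step of a 3.3-fold lower number from compound 2 to compound 3 (0.52 log units; beyond the scatter).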

Compound 3, half-maximal inhibitory concentration: 1770 nM
Compound 3: middle estimate off by 12-fold (1.07 log units), on the low side; measured number outside the range, above it.
By their numbers in this assay, from the lowest: compound 1; then compound 2; then compound 3.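

At this saturated ring carbon, the effect of replacing hydrogen depends on which group enters: in this assay, 4-fluorophenyl gives a 3.6-fold higher number from compound 2 to compound 3 (0.55 log units; beyond the scatter), whereas cyclopropyl at the same carbon gives a lower number than hydrogen. Hydrogen therefore falls between the two groups, and exchanging one group for the other gives a 13-fold higher number from compound 1 to compound 3 (1.11 log units; beyond the scatter), a large step that is wider than either step from hydrogen. The position is thus sensitive to the identity of its group, and the step from hydrogen to cyclopropyl cannot be read as a general gain for any group placed here.

No measurement shown here offers an explanation for why these two groups move the number in opposite directions. The three compounds also leave open whether the fluorine or the phenyl ring itself accounts for the higher number of compound 3, and how this carbon would respond to plain phenyl, a methyl group, a longer chain or an amine.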